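The source may report more compounds than this note shows. Statements on the series, on what has been measured and on what is new or still open speak of the compounds shown alone.

Compound 3 `CC[C@@H](Nc1c(C#N)c(-c2ccc(-c3cccc(C)c3F)cc2)nc2cnccc12)C(N)=O` has the highest reading of the three in a physicochemical assay for lipophilicity, read by HPLC, at pH 7.5 (on this read-out lower numbers stand for lower lipophilicity and higher numbers for higher lipophilicity), giving 3. Compound 1 `CC[C@@H](Nc1c(C#N)c(-c2ccc(-c3ccc(F)cc3)cc2)nc2cnccc12)C(N)=O` gives 2.7 in this assay, and the two lie within the scatter, since a number 0.30 log units higher from compound 1 to compound 3 (within the scatter). Compound 2 `CC[C@@H](Nc1c(C#N)c(-c2ccc(-c3ccncc3C)cc2)nc2cnccc12)C(N)=O` gives 2, and the gap is clear, since a number 1.00 log units higher from compound 2 to compound 3 (beyond the scatter). Compound 4 `CC[C@@H](Nc1c(C#N)c(-c2ccc(-c3ccccc3Cl)cc2)nc2cnccc12)C(N)=O` differs from compound 3 by 2-chlorophenyl in place of 2-fluoro-3-methylphenyl on an aromatic carbon. For the measured compounds named here, no measured step swaps these exact groups; the nearest is a number 0.30 log units higher from compound 1 to compound 3 (within the scatter), where a methyl and a relocated fluorine hardly moved this assay. A single chlorine replacing both substituents is therefore expected to leave the number close to that of compound 3, with a number 0.10 log units lower from compound 3 to compound 4 (within the scatter). Compound 4 is estimated at 2.9, within 2.5 to 3.3.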

Compound 4, distribution coefficient: 2.9
For compound 4 middle estimate and measured number coincide at the digits printed; measured number inside the range.
By their numbers in this assay, from the lowest: compound 2; then compounds 1, 4 and 3 (each within the scatter of the next).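

With 2-chlorophenyl at this position, on an aromatic carbon para to a large group, the reading in this assay stays with those of the other two phenyl groups, a number 0.10 log units lower from compound 3 to compound 4 (within the scatter) and a number 0.20 log units higher from compound 1 to compound 4 (within the scatter). A third phenyl group thus joins the cluster, and only the 3-methylpyridin-4-yl group stands apart, a number 0.90 log units higher from compound 2 to compound 4 (beyond the scatter). Nothing available here accounts for these readings.

On these data alone, how a phenyl ring carrying an amine or a carboxylic acid would read in this assay remains open.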